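Three Compounds at the Limit and a Methoxy Shift

The source may report more compounds than this note shows. Statements on the series, on what has been measured and on what is new or still open speak of the compounds shown alone.

The series studied here shares one core, varied only in the aryl group hanging from the five-membered aromatic ring with one nitrogen and one oxygen. Compound 3 (`COc1cccc(-c2cc(COC(Cc3cn(C4CCN(Cc5ccc([N+](=O)[O-])cc5)CC4)nn3)c3ccc(Br)cc3)on2)c1`) carries a 3-methoxyphenyl there. In a functional assay on MDA-MB-231 cells (Homo sapiens) for cytotoxicity, with a stated time of 48 h (a lower number here means a stronger inhibitor, a higher number a weaker inhibitor), compound 3 gives > 25000 nM, which is a limit of the assay rather than a number. Compound 1 (`O=[N+]([O-])c1ccc(CN2CCC(n3cc(CC(OCc4cc(-c5ccc(F)cc5)no4)c4ccc(Br)cc4)nn3)CC2)cc1`), with a 4-fluorophenyl, gives in this assay > 25000 nM, also a limit. Compound 2 (`COc1ccc(-c2cc(COC(Cc3cn(C4CCN(Cc5ccc([N+](=O)[O-])cc5)CC4)nn3)c3ccc(Br)cc3)on2)cc1`), with a 4-methoxyphenyl, gives in this assay > 25000 nM, again a limit. Accordingly the measured steps are a step that the two limits leave unreadable from compound 1 to compound 2, a step that the two limits leave unreadable from compound 1 to compound 3 and a step that the two limits leave unreadable from compound 2 to compound 3; all three remain unreadable in size, as all values sit at the limit of > 25000 nM in this assay, at which 3 of the 3 values shown sit.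

Compound 4 (`COc1ccccc1-c1cc(COC(Cc2cn(C3CCN(Cc4ccc([N+](=O)[O-])cc4)CC3)nn2)c2ccc(Br)cc2)on1`) differs from compound 3 by 2-methoxyphenyl in place of 3-methoxyphenyl on an aromatic carbon. Every measured step among the three aryl variants is unreadable, so no direction can be inferred for this shift of the methoxy around the ring. The expectation is therefore that the step from compound 3 to compound 4 is a step that the limit leaves unreadable from compound 3 to compound 4, with compound 4 most likely reported again as a limit. Compound 4 is estimated in this assay at 30000 nM, expected to fall between 8000 nM and 100000 nM.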

Compound 4, half-maximal inhibitory concentration: > 25000 nM
Compound 4 gave a limit, no number; the forecaster's own chance of this, stated with the estimate: 80%; the middle value is on the limit's open side.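

In this assay compound 4 gives > 25000 nM, again a limit. No step to compound 4 from compound 1, compound 2 or compound 3 can be read: the limit of > 25000 nM in this assay, at which 4 of the 4 values shown sit.

The compounds shown leave open whether moving the methoxy around the phenyl ring, or replacing 4-fluorophenyl, changes the result in this assay at all.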